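From (Phenylsulfonyl)amino to 4-Bromophenyl on a Shared Core

The source may report more compounds than this note shows. Statements on the series, on what has been measured and on what is new or still open speak of the compounds shown alone.

Of the compounds shown here, three built on one shared core have been tested in an ADME assay on WI-38 cells (Homo sapiens) for cytotoxicity, read by sulforhodamine B assay, with a stated time of 24 h; a higher number here means a weaker inhibitor, a lower number a stronger inhibitor. Compound 1 `O=C1Nc2ccc(S(=O)(=O)N3CCOCC3)cc2/C1=N/NS(=O)(=O)c1ccccc1` gives 302000 nM, the highest of the three numbers. Compound 2 `N=c1oc2ccccc2cc1C(=O)N/N=C1\C(=O)Nc2ccc(S(=O)(=O)N3CCOCC3)cc21` gives 132000 nM, a lower number that lies beyond the usual scatter of such measurements. Compound 3 `COc1ccc(-c2c(C#N)c(N)n(/N=C3\C(=O)Nc4ccc(S(=O)(=O)N5CCOCC5)cc43)c(=O)c2C#N)cc1` gives 224000 nM, which sits within the scatter of the number for compound 1, so no order between those two can be claimed.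

Compound 4 `O=C1Nc2ccc(S(=O)(=O)N3CCOCC3)cc2/C1=N/c1ccc(Br)cc1` has not yet been measured. It differs from compound 1 in one place: 4-bromophenyl in place of (phenylsulfonyl)amino on a double-bonded nitrogen. For the measured compounds named here, no measured pair in this set shows this change, so its effect cannot be read from the data. All three measured numbers fall in a narrow and high range, and the expectation is a step of a 1.2-fold lower number from compound 1 to compound 4 (0.08 log units; within the scatter), small and likely within the scatter. On that basis compound 4 is expected to give about 250000 nM in this assay, with a range from 120000 nM to 500000 nM.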

Compound 4, half-maximal inhibitory concentration: 372000 nM
Compound 4: middle estimate off by 1.5-fold (0.17 log units), on the low side; the range from low to high includes it.
By their numbers in this assay, from the lowest: compounds 2, 3, 1 and 4 (each within the scatter of the next, the first and the last beyond it).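

For the compounds shown here, this is the first direct one-place comparison: in this assay, placing 4-bromophenyl in place of (phenylsulfonyl)amino on a double-bonded nitrogen gives a 1.2-fold higher number from compound 1 to compound 4 (0.09 log units; within the scatter), so the two compounds cannot be told apart. The hydrogen-bond donor and acceptors of the departing group are absent from compound 4, yet this swap leaves no measurable difference, so in this pair they make no difference that the assay can detect. No supporting information explains this result.

On these data alone, both groups compared here contain a six-membered aromatic ring of carbon only, so it remains open whether a group without such a ring, such as a small amine or a carboxylic acid, would shift the number beyond the scatter. As far as these compounds go, the role of the bromine is also open, as a plain phenyl group on the same nitrogen would be needed to isolate it.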